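The source may report more compounds than this note shows. Statements on the series, on what has been measured and on what is new or still open speak of the compounds shown alone.

Compound 1 `CCN1CCN(c2cc(C)c3cc(NC(=O)c4cccc(Cl)c4)ccc3n2)CC1` is the point of departure. In a functional assay on SK-BR-3 cells (Homo sapiens) for antiproliferative activity, read by MTT assay, with a stated time of 72 h (on this read-out higher numbers stand for weaker inhibition and lower numbers for stronger inhibition), compound 1 gives 17800 nM, the lowest of the two numbers recorded there. For the measured compounds named here, its nearest neighbour is compound 3 `CCN1CCN(c2cc(C)c3cc(NC(=O)c4ccco4)ccc3n2)CC1`, which in this assay gives 37500 nM; the step of a 2.1-fold higher number from compound 1 to compound 3 (0.32 log units; beyond the scatter) is the only one-place change measured in this set. Compound 2 `Cc1cc(N(C)C)nc2ccc(NC(=O)c3ccc(Cl)c(Cl)c3)cc12` sits in this assay at the limit of the assay, > 50000 nM, and no number is known for it (the limit of > 50000 nM in this assay, at which 1 of the 3 values shown sits).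

Compound 4 `CCN1CCN(c2cc(C)c3cc(NC(=O)c4ccc(F)cc4)ccc3n2)CC1` differs from compound 1 in one place: 4-fluorophenyl in place of 3-chlorophenyl on a carbonyl carbon. Going by the values given here, no measured step swaps one halogenated phenyl for another, so the only guide is the step of a 2.1-fold higher number from compound 1 to compound 3 (0.32 log units; beyond the scatter), in which replacing the 3-chlorophenyl with a different ring on the carbonyl carbon gave a modest weakening. A change of similar or smaller size in this assay is therefore expected, most likely a small weakening or none beyond the scatter, the step of a 1.4-fold higher number from compound 1 to compound 4 (0.15 log units; within the scatter) being the estimate. For compound 4 in this assay the expected value is 25000 nM, with a range from 9000 nM to 70000 nM.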

Compound 4, half-maximal inhibitory concentration: 19800 nM
Compound 4: the middle estimate sits 1.3-fold (0.10 log units) above what was measured; low and high end bracket the measured number.
By their numbers in this assay, from the lowest: compounds 1, 4 and 3 (each within the scatter of the next, the first and the last beyond it). At a limit, above all of these: compound 2.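

In this assay the carbonyl carbon takes 4-fluorophenyl in place of 3-chlorophenyl with a 1.1-fold higher number from compound 1 to compound 4 (0.05 log units; within the scatter) and no change that can be told from the scatter, so this exchange of one halogenated phenyl for another leaves the read-out where it was. For the compounds shown here, the exchange of furan-2-yl for 4-fluorophenyl reads a 1.9-fold lower number from compound 3 to compound 4 (0.28 log units; within the scatter) and also stays within the scatter, which places 4-fluorophenyl close to both earlier groups, while a 2.1-fold higher number from compound 1 to compound 3 (0.32 log units; beyond the scatter) remains the only step here beyond it. Nothing given here offers a cause for these steps.

Still open, going by these compounds, is whether an unsubstituted phenyl or a saturated ring such as cyclohexyl on this carbonyl carbon would hold the number. Equally open, on these data alone, is what a phenyl bearing an amine or a carboxylic acid would do.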